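This account rests on a few compounds, and the source may have more. Where it says the series, first, only, none or still open, it means among the compounds named here.

In a functional assay on MCF7 cells (Homo sapiens) for cytotoxicity, read by MTT assay, with a stated time of 72 h (a lower number here means a stronger inhibitor, a higher number a weaker inhibitor), compound 1 `COc1c(OCCCCN2CCN(C)CC2)cc(O)c2c(=O)cc(-c3ccc(C)cc3)oc12` gives 4020 nM. Compound 2 `COc1c(OCCCCN2CCN(C)CC2)cc(O)c2c(=O)cc(-c3ccc(Br)cc3)oc12` gives 3210 nM, and compound 3 `COc1c(OCCCCN2CCN(C)CC2)cc(O)c2c(=O)cc(-c3ccc(F)cc3Br)oc12` gives 3090 nM. These three values lie within the usual scatter of one another, so compound 1 has no separate standing among them. Compound 4 `COc1c(OCCCCN2CCN(C)CC2)cc(O)c2c(=O)cc(-c3cccc(F)c3)oc12` has not yet been measured. It carries 3-fluorophenyl in place of 4-methylphenyl on an aromatic carbon next to the ring oxygen of the core, a change counted as 3-fluorophenyl in place of 4-methylphenyl on an aromatic carbon. Three measured steps exchange the phenyl group at this same place: a 1.3-fold lower number from compound 1 to compound 2 (0.10 log units; within the scatter), a 1.3-fold lower number from compound 1 to compound 3 (0.11 log units; within the scatter) and a 1.0-fold lower number from compound 2 to compound 3 (0.02 log units; within the scatter). Among the measured compounds shown here, none of them leaves the scatter, although none of the measured compounds carries 3-fluorophenyl. On the strength of these steps, this assay is expected to show no step beyond the scatter, and no direction can be expected. The estimated change is a 1.2-fold lower number from compound 1 to compound 4 (0.07 log units; within the scatter). For compound 4 the estimated value is 3400 nM, with an expected range from 1800 nM to 6500 nM.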

Compound 4, half-maximal inhibitory concentration: 2890 nM
Estimate against measurement, compound 4: 1.2-fold (0.07 log units) above, within the range that was stated.
By their numbers in this assay, from the lowest: compounds 4, 3, 2 and 1 (each within the scatter of the next).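

In this assay the step to 3-fluorophenyl stays within the scatter against 4-methylphenyl (a 1.4-fold lower number from compound 1 to compound 4 (0.14 log units; within the scatter)), against 2-bromo-4-fluorophenyl (a 1.1-fold lower number from compound 3 to compound 4 (0.03 log units; within the scatter)) and against 4-bromophenyl (a 1.1-fold lower number from compound 2 to compound 4 (0.05 log units; within the scatter)). The earlier compounds shown here all carried a group in the 4-position of the phenyl ring, so compound 4 extends the same flat picture to a phenyl ring with its single fluorine in the 3-position, and none of the four compounds stands apart from the others. Nothing available gives a reason for this evenness.

From the compounds shown here alone, it remains open whether an amine or a carboxylic acid on the phenyl ring, or a non-aromatic group such as cyclohexyl in its place, would move the number beyond the scatter. Also open, going by these compounds, is whether a longer chain elsewhere on the shared core would do so.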